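Naphthalen-1-yl to Phenethyl: What Compound 4 Might Show

This account rests on a few compounds, and the source may have more. Where it says the series, first, only, none or still open, it means among the compounds named here.

Of the compounds shown here, three built on one shared core have been tested in a functional assay on MRC5 cells (Homo sapiens); on this read-out higher numbers stand for lower toxicity in this test and lower numbers for higher toxicity in this test. Compound 1 `N#Cc1ccc(CN2c3ccccc3C(=O)N(Cc3ccccc3)S2(=O)=O)cc1` gives 62000 nM. For compound 2 `O=C1c2ccccc2N(CC2CCCCC2)S(=O)(=O)N1Cc1ccccc1` the assay reports only a limit, > 65000 nM. For compound 3 `O=C1c2ccccc2N(Cc2cccc3ccccc23)S(=O)(=O)N1Cc1ccccc1` the assay likewise reports only a limit, > 58000 nM. Compound 3 thus sits at the upper edge of the numbers shown, where the assay stops reading, as the limit of > 58000 nM in this assay, at which 1 of the 3 values shown sits, records. Compound 2 sits at a similar edge, as the limit of > 65000 nM in this assay, at which 1 of the 3 values shown sits, records. The step of an at least 1.0-fold higher number from compound 1 to compound 2 (0.02 log units; that floor lies within the scatter) lies within the scatter, while the steps a step that the limit leaves unreadable from compound 1 to compound 3 and a step that the two limits leave unreadable from compound 2 to compound 3 cannot be sized.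

Compound 4 `O=C1c2ccccc2N(CCCc2ccccc2)S(=O)(=O)N1Cc1ccccc1` differs from compound 3 by phenethyl in place of naphthalen-1-yl on a saturated chain carbon bound to a sulfonamide nitrogen in a ring. Among the measured compounds shown here, no measured step matches this change, and each group tried so far on that saturated chain carbon left the read-out at or near the top of the assay. Compound 4 is therefore expected to remain near that top in this assay, with a step that the limit leaves unreadable from compound 3 to compound 4 that is not expected to exceed the scatter. The estimate for compound 4 is 60000 nM, between 30000 nM and 120000 nM, and another limit rather than a number is the likelier report.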

Compound 4, half-maximal cytotoxic concentration: > 57000 nM
Compound 4: no number, only a limit; the forecaster's own chance of this, stated with the estimate: 60%; the middle value is on the limit's open side.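

In this assay compound 4 gives only a limit, > 57000 nM. None of its steps from compound 1, compound 2 or compound 3 can be read. The compounds shown leave open whether the groups on the saturated chain carbon of compound 2, compound 3 and compound 4 differ at all in this assay.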